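Swapping the Sulfur-Linked Aryl Group in a Growth Inhibitor Series

This account rests on a few compounds, and the source may have more. Where it says the series, first, only, none or still open, it means among the compounds named here.

Three compounds share one core and differ only in the group carried on a sulfur. In a functional assay on SMMC-7721 cells (Homo sapiens) for inhibition, read by CCK-8 assay, with a stated time of 72 h, tested at 2 uM (on this read-out higher numbers stand for more inhibition of growth at the one concentration tested and lower numbers for less inhibition of growth), compound 3 `Nc1ccccc1NC(=O)/C=C/c1ccc(CSc2ccc(C(F)(F)F)cn2)cc1` gives 12.1%, the second highest of the three numbers. Compound 1 `Nc1ccccc1NC(=O)/C=C/c1ccc(CSc2ccc(Cl)cc2)cc1` gives 15.2%, and compound 2 `Nc1ccccc1NC(=O)/C=C/c1ccc(CSc2cccc3ccccc23)cc1` gives 3.7%. The step of a number 3.1 percentage points lower from compound 1 to compound 3 (within the scatter) stays within the scatter, a number 8.4 percentage points higher from compound 2 to compound 3 (within the scatter) also stays within it, while a number 11.5 percentage points lower from compound 1 to compound 2 (beyond the scatter) goes beyond it. Compound 4 `CCc1ccc(SCc2ccc(/C=C/C(=O)Nc3ccccc3N)cc2)cc1` has not yet been measured; it differs from compound 3 by 4-ethylphenyl in place of 5-(trifluoromethyl)pyridin-2-yl on a sulfur. The step of a number 1.9 percentage points higher from compound 3 to compound 4 (within the scatter) is expected to stay within the scatter, because the comparable step a number 3.1 percentage points lower from compound 1 to compound 3 (within the scatter) also did. Compound 4 is therefore estimated at 14%, with a range from 4% to 24%.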

Compound 4, percent growth inhibition at one concentration: 13.2%
Compound 4: middle estimate off by 0.8 percentage points, on the high side; the measured number falls inside the stated range.
By their numbers in this assay, from the lowest: compounds 2, 3, 4 and 1 (each within the scatter of the next, the first and the last beyond it).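

In this assay, 4-ethylphenyl on the sulfur, a ring of carbon only, gives a number 1.1 percentage points higher from compound 3 to compound 4 (within the scatter) and a number 2 percentage points lower from compound 1 to compound 4 (within the scatter), so neither the ring nitrogen and trifluoromethyl of compound 3 nor the chloro of compound 1 can be told apart from it here. The third step, a number 9.5 percentage points higher from compound 2 to compound 4 (within the scatter), means compound 4 also cannot be separated from compound 2, although compound 1 and compound 2 do differ beyond the scatter. No measured evidence bears on why these numbers fall as they do.

Open, on these data alone, is whether a group without a ring on the sulfur, such as a longer chain, or an aromatic ring carrying an amine or a carboxylic acid, would give a number beyond the scatter.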